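The compounds below may be only part of what the source reports. "The series", "measured", "known", "first", "only" and "open" are said of these compounds alone.

Measured so far:
compound 1, `CSc1ccc(S(=O)(=O)NC(=O)Nc2ccc(Cl)cc2)s1`: 29%
compound 2, `Cc1ccsc1S(=O)(=O)NC(=O)Nc1ccc(Cl)cc1`: 17%

In a functional assay on the whole organism (6C3HED cells, Mus musculus) for inhibition, at a dose of 150 mg/kg by the oral route (a higher number here means more inhibition at the dose given (going by the name of the read-out), a lower number less inhibition), compound 1 gives 29% and compound 2 gives 17%. Compound 2 thus stands lowest of the two numbers, the step of a number 12 percentage points lower from compound 1 to compound 2 (beyond the scatter) lying beyond the scatter. Compound 3, `CCc1csc(S(=O)(=O)NC(=O)Nc2ccc(Cl)cc2)c1`, differs from compound 2 by a group of 7 heavy atoms (6 carbon, 1 sulfur; one five-membered aromatic ring with 1 hetero atom) in place of a group of 6 heavy atoms (5 carbon, 1 sulfur; one five-membered aromatic ring with 1 hetero atom), on a sulfonyl sulfur. Within the data shown here, the single measured step, a number 12 percentage points lower from compound 1 to compound 2 (beyond the scatter), concerns the same sulfonyl sulfur but exchanges a different pair of groups, so it shows only that changes at this position can move the inhibition modestly; it gives no direction for the present exchange. With one carbon more on the ring group, the step from compound 2 to compound 3 is expected to stay within the scatter. Compound 3 is therefore estimated to give 20%, in the range 5% to 40%, which means an expected step of a number 3 percentage points higher from compound 2 to compound 3 (within the scatter).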

Compound 3, a percentage reported as inhibition, in the whole organism at one dose (the size of the read-out at that dose, not a potency): 55%
Beside the measured number, compound 3's estimate is 35 percentage points below it, outside the stated range (above it).
By their numbers in this assay, from the lowest: compound 2; then compound 1; then compound 3.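

In this assay the exchange of 3-methylthiophen-2-yl for a group of 7 heavy atoms, with the same five-membered aromatic ring, gives a number 38 percentage points higher from compound 2 to compound 3 (beyond the scatter) on a sulfonyl sulfur, so a small change in atom count at this place can produce a large move. The same group gives a number 26 percentage points higher from compound 1 to compound 3 (beyond the scatter) when it replaces the 5-(methylsulfanyl)thiophen-2-yl group, which shows that this position can raise the inhibition at the dose given as well as lower it, whereas the earlier step showed only a fall. Nothing among the data available here accounts for the size of these steps.

The compounds shown leave open whether a longer chain, such as propyl, on this ring would raise the inhibition further or lose it. They also leave open how an amine or a carboxylic acid would fare on the same ring.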